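Swapping an Aromatic Ring for a Saturated One

The source may report more compounds than this note shows. Statements on the series, on what has been measured and on what is new or still open speak of the compounds shown alone.

Measured compounds in a functional assay on MCF7 cells (Homo sapiens) for inhibition, read by MTT assay, with a stated time of 72 h; on this read-out higher numbers stand for weaker inhibition and lower numbers for stronger inhibition:
Compound 1, `Cc1cc(Nc2cc(-c3ccccc3)[nH]n2)n2nc(SCc3ccc(Cl)cc3)nc2n1`, gives 8260 nM.
Compound 2, `Cc1cc(Nc2cc(-c3ccccc3)[nH]n2)n2nc(SCc3cccc4ccccc34)nc2n1`, gives 7560 nM.
Compound 3, `Cc1cc(Nc2cc(-c3ccccc3)[nH]n2)n2nc(SCc3ccc(Br)cc3)nc2n1`, gives 2720 nM.

Compound 3 is the strongest of the three: the step of a 3.0-fold lower number from compound 1 to compound 3 (0.48 log units; beyond the scatter) and the step of a 2.8-fold lower number from compound 2 to compound 3 (0.44 log units; beyond the scatter) both go beyond the scatter, while a 1.1-fold lower number from compound 1 to compound 2 (0.04 log units; within the scatter) does not. Compound 4, `Cc1cc(Nc2cc(-c3ccccc3)[nH]n2)n2nc(SCC3CCCCC3)nc2n1`, is not yet measured; it differs from compound 3 by cyclohexyl in place of 4-bromophenyl on a saturated chain carbon bound to a sulfur. The two measured steps that change the group on this carbon were modest in size, yet neither replaces an aromatic ring with a non-aromatic one, so they guide the size of this step only loosely. Compound 4 is expected to give a somewhat higher number, estimated at 5500 nM within 1800 nM to 17000 nM. The expected step is a 2.0-fold higher number from compound 3 to compound 4 (0.31 log units; beyond the scatter).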

Compound 4, half-maximal inhibitory concentration: > 50000 nM
Compound 4 gave a limit, no number; the forecaster's own chance of this, stated with the estimate: 10%; at least 9.0-fold (0.95 log units) between middle value and limit.
By their numbers in this assay, from the lowest: compound 3; then compounds 2 and 1 (each within the scatter of the next). At a limit, above all of these: compound 4.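

Compound 4 reads only as a limit of the assay, not as a number: the limit of > 50000 nM in this assay, at which 1 of the 4 values shown sits.

Among the aromatic groups on this carbon the steps were modest at most, but the one non-aromatic ring shown costs far more, with an at least 18-fold higher number from compound 3 to compound 4 (1.26 log units; beyond the scatter) and an at least 6.6-fold higher number from compound 2 to compound 4 (0.82 log units; beyond the scatter) and also an at least 6.0-fold higher number from compound 1 to compound 4 (0.78 log units; beyond the scatter). In these four compounds, then, an aromatic ring at this position goes with a measurable number, and cyclohexyl does not.

Still open, on these data alone, is whether aromaticity itself is what counts here. An unsubstituted phenyl, a pyridine ring or a longer alkyl chain on this carbon would help to answer that.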